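Moving Two Fluorines Around a Benzyl Ring

The compounds below may be only part of what the source reports. "The series", "measured", "known", "first", "only" and "open" are said of these compounds alone.

Compound 1 `CC1(C)c2[nH]nc(NC(=O)c3ccccc3)c2CN1Cc1cccc(Br)c1` carries a 3-bromophenyl on the saturated chain carbon bound to the ring amine nitrogen; in an assay on Sf21 cells for inhibition of high affinity nerve growth factor receptor (Homo sapiens), read by HTRF, with a stated time of 30 min, in the presence of a further agent that is not named here (a lower number here means a stronger inhibitor, a higher number a weaker inhibitor), compound 1 gives 940 nM. In this assay compound 2 `CC1(C)c2[nH]nc(NC(=O)c3ccccc3)c2CN1Cc1cccc(F)c1F` gives 200 nM, and compound 3 `CC1(C)c2[nH]nc(NC(=O)c3ccccc3)c2CN1Cc1ccc(F)c(F)c1` gives 680 nM. Of these three numbers compound 3 stands second highest; the step of a 1.4-fold lower number from compound 1 to compound 3 (0.14 log units; within the scatter) lies within the usual spread of repeat measurements, whereas a 3.4-fold higher number from compound 2 to compound 3 (0.53 log units; beyond the scatter) and a 4.7-fold lower number from compound 1 to compound 2 (0.67 log units; beyond the scatter) both lie beyond it.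

Compound 4 `CC1(C)c2[nH]nc(NC(=O)c3ccccc3)c2CN1Cc1ccc(F)cc1F` has not been measured. It differs from compound 3 by 2,4-difluorophenyl in place of 3,4-difluorophenyl on a saturated chain carbon bound to an amine nitrogen in a ring. Among the measured compounds shown here, the only measured step that rearranges two fluorines on this ring is the one between compound 2 and compound 3, and it was modest in size. A rearrangement of the same kind is therefore expected to give at most a modest change for compound 4, most likely toward a lower number: a 1.9-fold lower number from compound 3 to compound 4 (0.29 log units; within the scatter). Compound 4 is expected to show about 350 nM in this assay, within 150 nM to 800 nM.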

Compound 4, half-maximal inhibitory concentration: 2320 nM
Estimate against measurement, compound 4: 6.6-fold (0.82 log units) below; the measured number lies above the stated range.
By their numbers in this assay, from the lowest: compound 2; then compounds 3 and 1 (each within the scatter of the next); then compound 4.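

The two fluorines do not act as a simple sum on this ring: 2,3-difluorophenyl and 2,4-difluorophenyl differ only in where one fluorine sits, yet in this assay the change gives a 12-fold higher number from compound 2 to compound 4 (1.06 log units; beyond the scatter) and is the only large step among these compounds. The new arrangement also does worse than the other two benzyl groups, with a 3.4-fold higher number from compound 3 to compound 4 (0.53 log units; beyond the scatter) and a 2.5-fold higher number from compound 1 to compound 4 (0.39 log units; beyond the scatter), so a fluorine named at the 2 position appears in both the best and the worst of the four compounds. Nothing available explains why these arrangements of the same atoms differ so much.

Going by these compounds, whether the low number of compound 2 needs both of its fluorines remains open. So does how an unsubstituted phenyl, a chlorine or a methoxy group would behave on this ring.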